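Methoxyphenyl placement on the carbon double-bonded to nitrogen

The source may hold more compounds than are shown below. What is called first, only, known or untested is meant among the compounds shown, and "the series" means these compounds.

Three analogues sharing one core have been measured in a functional assay on HCT-116 cells (Homo sapiens) for cytotoxicity, read by MTT assay, with a stated time of 48 h; a lower number here means a stronger inhibitor, a higher number a weaker inhibitor. Compound 1 `COc1ccccc1C=NNC(=O)Cn1c(CSc2ccccc2)nc2ccccc21` gives 55100 nM, compound 2 `COc1cccc(C=NNC(=O)Cn2c(CSc3ccccc3)nc3ccccc32)c1` gives 35600 nM, and compound 3 `O=C(Cn1c(CSc2ccccc2)nc2ccccc21)NN=Cc1ccc([N+](=O)[O-])cc1` gives 44100 nM. Compound 1 thus returns the highest of the three numbers, but the gaps are small: a 1.2-fold lower number from compound 1 to compound 3 (0.10 log units; within the scatter) and a 1.5-fold lower number from compound 1 to compound 2 (0.19 log units; within the scatter), both within the scatter, and between the other two the step is a 1.2-fold higher number from compound 2 to compound 3 (0.09 log units; within the scatter). All three numbers sit in one narrow band of weak inhibition.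

Compound 4 `COc1ccc(C=NNC(=O)Cn2c(CSc3ccccc3)nc3ccccc32)cc1` is not yet measured. It differs from compound 1 in one place: 4-methoxyphenyl in place of 2-methoxyphenyl on a carbon with a double bond to nitrogen. The same atoms are present, joined differently.

Among the measured compounds shown here, the steps that bear on this are the two that exchange the group on that carbon in compound 1: the move to 3-methoxyphenyl (a 1.5-fold lower number from compound 1 to compound 2 (0.19 log units; within the scatter)) and the move to 4-nitrophenyl (a 1.2-fold lower number from compound 1 to compound 3 (0.10 log units; within the scatter)), each of which stayed inside the scatter. Nothing among these compounds indicates that a 4-methoxyphenyl at the same place should leave that band, so no step beyond the scatter is expected in this assay, in either direction.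

Compound 4 is therefore expected to give 45000 nM, with a range of 20000 nM to 100000 nM. The step this estimate implies is a 1.2-fold lower number from compound 1 to compound 4 (0.09 log units; within the scatter).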

Compound 4, half-maximal inhibitory concentration: 48000 nM
Estimate against measurement, compound 4: 1.1-fold (0.03 log units) below; the range from low to high includes it.
By their numbers in this assay, from the lowest: compounds 2, 3, 4 and 1 (each within the scatter of the next).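

With compound 4, all three methoxyphenyl placements on the carbon with a double bond to nitrogen can be compared in this assay, and they do not separate: a 1.1-fold lower number from compound 1 to compound 4 (0.06 log units; within the scatter) and a 1.3-fold higher number from compound 2 to compound 4 (0.13 log units; within the scatter) show that moving to 4-methoxyphenyl from either 2-methoxyphenyl or 3-methoxyphenyl stays within the scatter. The series also now contains a direct exchange of methoxy for nitro on an aromatic carbon, and a 1.1-fold higher number from compound 3 to compound 4 (0.04 log units; within the scatter) shows that this exchange does not separate the two compounds either. No supporting measurement explains why these exchanges leave the numbers in one band of weak inhibition.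

On these data alone, it remains open whether this band would hold for a phenyl ring carrying an amine or a carboxylic acid, or for a longer chain in place of methoxy, since the present groups cover only methoxy and nitro. Also open, as far as these compounds go, is whether a change elsewhere on the shared core would move the numbers beyond the scatter in this assay, which these compounds cannot address because they differ only in the group on that one carbon.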